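Ring stereocentre inversion at the stability limit

The source may hold more compounds than are shown below. What is called first, only, known or untested is meant among the compounds shown, and "the series" means these compounds.

In an ADME assay (Mus musculus, strain C57BL/6) for metabolic stability, read by HPLC, with a stated time of 12 h (a higher number here means that the compound lasts longer, a lower number that the compound disappears faster), compound 2 (`O=C(O)[C@H](CO)NC(=O)[C@H]1C[C@@H](O)CN1`) gives > 12 h as a limit, not a number. Compound 1 (`O=C(O)[C@@H](CO)NC(=O)[C@H]1C[C@@H](O)CN1`) gives > 12 h as a limit too. Compound 3 (`O=C(O)[C@H](CO)NC(=O)[C@@H]1C[C@@H](O)CN1`) arises from compound 2 by one change, the two compounds have the same atoms and bonds and differ only in configuration as drawn: 1 of 3 stereo elements differ; a stereocentre at a saturated ring carbon is drawn R in compound 2 and S in compound 3 with no group leaving or entering.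

For the measured compounds named here, the only measured step bearing on this is a step that the two limits leave unreadable from compound 1 to compound 2 and, as the fact that compounds 1 and 2 differ only in the configuration as drawn shows, it also concerns configuration alone, though at a saturated chain carbon rather than a saturated ring carbon. Going by these compounds, its size stays open given the limit of > 12 h in this assay, at which 2 of the 2 values shown sit, and no inversion at the ring carbon has been measured. In this assay no step beyond the scatter is expected, and no direction is favoured. The estimated step is a step that the limit leaves unreadable from compound 2 to compound 3 with a limit reading the likely outcome. Compound 3 is expected at 14 h within an estimated range of 8 h to 24 h in this series.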

Compound 3, half-life: 0.88 h
Estimate against measurement, compound 3: 16-fold (1.20 log units) above; the measured number lies below the stated range.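

In this assay, the inversion at the saturated ring carbon produces an at least 13-fold lower number from compound 2 to compound 3 (1.13 log units; beyond the scatter), so configuration at this position separates the compounds in a way that the earlier pair, both at a limit, could not show. No group leaves or enters in this step: the fact that compounds 2 and 3 differ only in the configuration as drawn. The step of an at least 13-fold lower number from compound 1 to compound 3 (1.13 log units; beyond the scatter) spans both the saturated chain carbon and the saturated ring carbon, so it cannot be assigned to either stereocentre alone.

Going by these compounds, the full size of both steps stays open, and the step between the two compounds at the limit cannot be read; the effect of the chain carbon with the ring carbon drawn S is also unknown. On these data alone, whether a methyl ester in place of the carboxylic acid, or a fluorine on the ring carbon, would keep this dependence on configuration remains open.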